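Cyano on the fused ring of compound 1

A few compounds are considered here, and "the series" means these few. Any claim that something is new, unique, unknown or untested is made for them only; others in the source may bear on it.

Three amides on the shared core have been measured in a functional assay on A549 cells (Homo sapiens) for antiproliferative activity, read by MTT assay, with a stated time of 72 h; a lower number here means a stronger inhibitor, a higher number a weaker inhibitor. Compound 1 `CN(C(=O)c1ccccc1)c1ccc2[nH]c(-c3n[nH]c4ccccc34)cc2n1` gives 13800 nM. Compound 2 `CN(C(=O)CCc1ccccc1)c1ccc2[nH]c(-c3n[nH]c4ccccc34)cc2n1` gives 18100 nM, and compound 3 `COc1ccc(C(=O)N(C)c2ccc3[nH]c(-c4n[nH]c5ccccc45)cc3n2)cc1` gives 14600 nM. Compound 1 holds the lowest of the three numbers, yet a 1.3-fold higher number from compound 1 to compound 2 (0.12 log units; within the scatter) and a 1.1-fold higher number from compound 1 to compound 3 (0.02 log units; within the scatter) both lie within the scatter, as does a 1.2-fold lower number from compound 2 to compound 3 (0.09 log units; within the scatter). Across these three compounds no change on the carbonyl side has moved the number beyond scatter.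

Compound 4 `CN(C(=O)c1ccccc1)c1ccc2[nH]c(-c3n[nH]c4cc(C#N)ccc34)cc2n1` alters a different part of the molecule: cyano in place of hydrogen on an aromatic carbon. All three measured steps concern the group on the carbonyl carbon; none of them touches the fused ring of the core. Going by the values given here, no measured step therefore bears directly on this change, and the only guide is the flat set of numbers seen so far. With no basis for a direction, a step within the scatter is expected, a 1.0-fold higher number from compound 1 to compound 4 (0.01 log units; within the scatter). Compound 4 is accordingly estimated at 14000 nM in this assay, with an expected range from 5000 nM to 40000 nM. Among the compounds with values here, the range is set wide; no measured compound varies this position.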

Compound 4, half-maximal inhibitory concentration: 32800 nM
For compound 4 the middle estimate is 2.3-fold (0.37 log units) below the measured one; low and high end bracket the measured number.
By their numbers in this assay, from the lowest: compounds 1, 3, 2 and 4 (each within the scatter of the next, the first and the last beyond it).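

In this assay, going by these compounds alone, the fused ring of the core is the first place where a single change moves the number beyond the scatter: cyano in place of hydrogen gives a 2.4-fold higher number from compound 1 to compound 4 (0.38 log units; beyond the scatter) and so a modest step towards a weaker inhibitor. The three amides showed only a flat response to the group on the carbonyl carbon, whereas this aromatic carbon of the six-membered ring does respond, and a nitrile here goes with a higher number rather than a lower one. No measurement in hand accounts for this step.

Going by these compounds, whether the step belongs to cyano alone or to any group at this position remains open, and a single substituent cannot settle it: fluorine, methoxy, an amine or a carboxylic acid on the same carbon would separate the two readings. Also open, on these data alone, are whether cyano would give a step of similar size on compound 2 or compound 3, and whether the other carbons of this ring respond in the same way.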